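Side-chain length and cytotoxicity: compound 2 to compound 3

The source may hold more compounds than are shown below. What is called first, only, known or untested is meant among the compounds shown, and "the series" means these compounds.

Compound 1 `CCCCCCCNc1cnc(C(=O)NCc2ccccc2)cn1` and compound 2 `CCCCNc1cnc(C(=O)NCc2ccccc2)cn1` share the same core and differ only in the length of the saturated chain. In an ADME assay on Vero cells (Chlorocebus sabaeus) for cytotoxicity, read by microscopy, with a stated time of 6 days (on this read-out lower numbers stand for higher toxicity in this test and higher numbers for lower toxicity in this test), compound 1 gives >= 100000 nM, which is a limit of the assay and not a number. In this assay compound 2 gives > 100000 nM, also a limit. The step that the two limits leave unreadable from compound 1 to compound 2 is not readable, since both values sit at limits (the limit of > 100000 nM in this assay, at which 1 of the 2 values shown sits, (the limit of >= 100000 nM in this assay, at which 1 of the 2 values shown sits)). Compound 2 thus stands at the upper edge of what this assay reports, with no numeric value of its own.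

Compound 3 `CCCCCCCCNc1cnc(C(=O)NCc2ccccc2)cn1` differs from compound 2 by butyl in place of hydrogen on a saturated chain carbon, four bonds along the chain from a nitrogen on an aromatic ring. Among the measured compounds shown here, the only measured step, from compound 1 to compound 2, touches the same position, but its size cannot be read, so no measured step gives a usable size for the change into compound 3. The expectation rests only on both measured compounds sitting at the limit. The expected step, a number no higher from compound 2 to compound 3 (the limit leaves the size open), is none beyond the scatter. Compound 3 is expected to give about 100000 nM, between 40000 nM and 200000 nM, most likely again reported only as a limit.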

Compound 3, minimum cytotoxic concentration: 20000 nM
Compound 3: middle estimate off by 5.0-fold (0.70 log units), on the high side, outside the stated range (below it).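

In this assay this chain position now gives a readable effect: butyl in place of hydrogen on a saturated chain carbon, four bonds along the chain from a nitrogen on an aromatic ring, gives an at least 5.0-fold lower number from compound 2 to compound 3 (0.69 log units; beyond the scatter), on the side of higher toxicity in this test. Methyl in place of hydrogen on a saturated chain carbon, seven bonds along the chain from a nitrogen on an aromatic ring, gives an at least 5.0-fold lower number from compound 1 to compound 3 (0.69 log units; beyond the scatter), so this single added methyl already separates compound 3 from compound 1 beyond the scatter. Both sizes are open-ended and the step between compound 1 and compound 2 cannot be read, because the values of those two compounds are limits of the assay: the limit of > 100000 nM in this assay, at which 1 of the 3 values shown sits.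

Going by these compounds, whether the number in this assay keeps falling with a longer chain or levels off remains open. Also open, on these data alone, is whether a chain carrying an amine or a carboxylic acid at its far end would stay with compound 3 or return to the limit seen for compound 2.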